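The source may report more compounds than this note shows. Statements on the series, on what has been measured and on what is new or still open speak of the compounds shown alone.

Working notes on the series built on one shared core. Compound 1 `CCOC(=O)C1=Cc2ccccc2OC1(OCc1cn(CC(=O)Nc2ccccc2Br)nn1)C(F)(F)F` gives in a functional assay on A549 cells (Homo sapiens) for inhibition, read by MTT assay, with a stated time of 24 h (on this read-out lower numbers stand for stronger inhibition and higher numbers for weaker inhibition), only a limit, > 150000 nM; this is the limit of > 150000 nM in this assay, at which 1 of the 3 values shown sits. Compound 2 `CCOC(=O)C1=Cc2ccccc2OC1(OCc1cn(CC(=O)Nc2ccc(C)cc2)nn1)C(F)(F)F` gives 54300 nM in this assay, the step being an at least 2.7-fold lower number from compound 1 to compound 2 (0.44 log units; beyond the scatter). Compound 3 `CCOC(=O)C1=Cc2ccccc2OC1(OCc1cn(-c2ccc(F)c([N+](=O)[O-])c2)nn1)C(F)(F)F` gives 11900 nM, with an at least 12-fold lower number from compound 1 to compound 3 (1.10 log units; beyond the scatter) and a 4.6-fold lower number from compound 2 to compound 3 (0.66 log units; beyond the scatter); compound 3 therefore stands lowest of the two numbers, separated from compound 2 beyond the scatter. Compound 4 `CCOC(=O)C1=Cc2ccccc2OC1(OCc1cn(-c2cccc(C(F)(F)F)c2)nn1)C(F)(F)F` differs from compound 3 by 3-(trifluoromethyl)phenyl in place of 4-fluoro-3-nitrophenyl on an aromatic nitrogen. Among the compounds with values here, both measured steps into compound 3 replace a carbamoylmethyl chain on the aromatic nitrogen with an aryl group; none replaces one aryl group with another, so no measured step bears directly on this change. The expected step is therefore a 1.3-fold higher number from compound 3 to compound 4 (0.13 log units; within the scatter), within the scatter or slightly toward weaker inhibition. Compound 4 is estimated at 16000 nM, between 5000 nM and 50000 nM.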

Compound 4, half-maximal inhibitory concentration: > 150000 nM
Compound 4: only a limit was reported (the forecaster's own chance of this, stated with the estimate: 5%); middle value at least 9.3-fold (0.97 log units) away from the limit.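

Within the data shown here, on the aromatic nitrogen, this is the first change of one aryl group for another, and it reads an at least 12-fold higher number from compound 3 to compound 4 (1.10 log units; beyond the scatter), so in this assay the result depends on which aryl group sits there, not merely on having one. Replacing the carbamoylmethyl chain with an aryl group also no longer gives a lower number every time, since the step reads an at least 2.7-fold higher number from compound 2 to compound 4 (0.44 log units; beyond the scatter). Compound 4 gives only a limit, as does compound 1: the limit of > 150000 nM in this assay, at which 2 of the 4 values shown sit.

The step between these two limits cannot be read. On these data alone, whether the nitro group or the fluorine of compound 3 matters remains open, as does whether an amine or a carboxylic acid in place of the nitro group would keep a measurable value.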